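Opening the oxetane ring at the core nitrogen

The source may report more compounds than this note shows. Statements on the series, on what has been measured and on what is new or still open speak of the compounds shown alone.

Measured so far:
compound 1 `COc1cc2c(cc1NS(=O)(=O)c1cccc(Cl)c1Cl)[nH]c(=O)n2C` gives 200 nM in a functional assay on CHO cells for antagonist activity at C-C chemokine receptor type 4 (Homo sapiens), read by radioligand binding and GTPgammaS binding; on this read-out lower numbers stand for stronger inhibition and higher numbers for weaker inhibition
compound 2 `COc1cc2c(cc1NS(=O)(=O)c1cccc(Cl)c1Cl)[nH]c(=O)n2C1COC1` gives 112 nM in this assay

For the measured compounds named here, compound 2 gives the smaller of the two numbers measured so far, but the gap a 1.8-fold lower number from compound 1 to compound 2 (0.25 log units; within the scatter) lies within the scatter of repeated measurements, so the two compounds cannot be told apart on this evidence. Compound 3 `COc1cc2c(cc1NS(=O)(=O)c1cccc(Cl)c1Cl)[nH]c(=O)n2C(CO)CO` is the next step on the same nitrogen of the shared core: 2-hydroxy-1-(hydroxymethyl)ethyl in place of oxetan-3-yl on an aromatic nitrogen. Going by the values given here, only one measured step bears on this position, the one from compound 1 to compound 2, in which a methyl gave way to oxetan-3-yl and the number moved by a 1.8-fold lower number from compound 1 to compound 2 (0.25 log units; within the scatter), within the scatter. That single step suggests this nitrogen tolerates substituents of different shape without large shifts, though nothing measured yet carries hydrogen-bond donors there. For compound 3 the expectation is therefore a step of about a 1.3-fold higher number from compound 2 to compound 3 (0.13 log units; within the scatter) in this assay, not clearly beyond the scatter in either direction. The estimate for compound 3 in this assay is 150 nM, with a range from 50 nM to 450 nM.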

Compound 3, half-maximal inhibitory concentration: 1580 nM
For compound 3 the middle estimate is 11-fold (1.02 log units) below the measured one, and the stated range ends below it.
By their numbers in this assay, from the lowest: compounds 2 and 1 (each within the scatter of the next); then compound 3.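

This position is less forgiving than the first two compounds suggested. In this assay the open 2-hydroxy-1-(hydroxymethyl)ethyl chain brings a 14-fold higher number from compound 2 to compound 3 (1.15 log units; beyond the scatter) and also a 7.9-fold higher number from compound 1 to compound 3 (0.90 log units; beyond the scatter) so it stands apart from both the oxetan-3-yl and the methyl compounds, which could not be told apart from each other. The tolerance seen earlier therefore covers only those two groups, neither of which has a hydrogen-bond donor, and it does not extend to every group of similar size on this aromatic nitrogen. Nothing available here explains the loss.

The step from compound 2 to compound 3 removes a ring and adds hydroxyl groups in one move, so the compounds shown leave open which of these two changes goes with the higher number. A 2-hydroxyethyl chain, or the same branched chain with methoxy groups in place of the hydroxyl groups, would separate the two, and an amine or a carboxylic acid at this nitrogen remains an open case.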